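Aryl change on the shared core: outlook for compound 3

A few compounds are considered here, and "the series" means these few. Any claim that something is new, unique, unknown or untested is made for them only; others in the source may bear on it.

Values in a functional assay on HL-60 cells (Homo sapiens) for cytotoxicity, read by CellTiter-Blue, with a stated time of 48 h (on this read-out higher numbers stand for weaker inhibition and lower numbers for stronger inhibition), so far:
- compound 1 `CCOC(=O)CC1C(C(=O)OCC)=C(N)Oc2ccc(-c3ccc(F)cc3)cc21` gives 72100 nM
- compound 2 `CCOC(=O)CC1C(C(=O)OCC)=C(N)Oc2ccc(-c3cc(F)cc(F)c3)cc21` gives 35900 nM

Compound 2 cannot be told apart from compound 1 on these numbers. The measured change is a 2.0-fold lower number from compound 1 to compound 2 (0.30 log units; within the scatter), so the pair gives no ranking.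

Compound 3 `CCOC(=O)CC1C(C(=O)OCC)=C(N)Oc2ccc(-c3cccnc3)cc21` keeps the shared core and carries pyridin-3-yl in place of 3,5-difluorophenyl on an aromatic carbon, the difference being (pyridin-3-yl in place of 3,5-difluorophenyl on an aromatic carbon). For the measured compounds named here, only the one measured step bears on this change, and it exchanges one fluorine-bearing phenyl group for another. Going by the values given here, no measured compound has an aromatic ring with a hetero atom at this place, so the evidence for the new ring is thin. Among the compounds with values here, with a 2.0-fold lower number from compound 1 to compound 2 (0.30 log units; within the scatter) as the sole guide, no step beyond the scatter is expected in this assay, and the direction stays open. The estimated change is a 1.4-fold higher number from compound 2 to compound 3 (0.14 log units; within the scatter) and the range is kept wide. For compound 3 the expected value is 50000 nM, with an estimated range of 18000 nM to 130000 nM.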

Compound 3, half-maximal inhibitory concentration: 21500 nM
Beside the measured number, compound 3's estimate is 2.3-fold (0.37 log units) above it; the range from low to high includes it.
By their numbers in this assay, from the lowest: compounds 3, 2 and 1 (each within the scatter of the next, the first and the last beyond it).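

In this assay, for the compounds shown here, pyridin-3-yl is the first ring with a hetero atom at this aromatic carbon, and exchanging it for 3,5-difluorophenyl gives a 1.7-fold lower number from compound 2 to compound 3 (0.22 log units; within the scatter), which leaves compound 2 and compound 3 without a ranking. Exchanging 4-fluorophenyl for the same ring gives a 3.4-fold lower number from compound 1 to compound 3 (0.53 log units; beyond the scatter), a modest step and the only one among these compounds beyond the scatter, so an aryl change at this position can register in this read-out even though each step involving compound 2 stays within the scatter. Nothing available on these compounds bears on the result, so no cause can be assigned to either step.

Going by these compounds, all three groups at this position are six-membered aromatic rings, so it remains open how a saturated amine such as morpholine, or a phenyl ring carrying a carboxylic acid, would compare. Also open, on these data alone, is whether pyridin-2-yl or pyridin-4-yl would match pyridin-3-yl, which would show whether the place of the ring nitrogen matters at all.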